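From Acetyl to Benzyl in an Inactive Set

The compounds below may be only part of what the source reports. "The series", "measured", "known", "first", "only" and "open" are said of these compounds alone.

In a functional assay on HOS cells (Homo sapiens) for antiproliferative activity, read by sulforhodamine B assay (a lower number here means a stronger inhibitor of growth, a higher number a weaker inhibitor of growth), compound 1 `CC[C@@H]1O[C@H](COCc2ccccc2)[C@@H](OCc2ccccc2)[C@H](OCc2ccccc2)[C@H]1OC(C)=O` gives > 50000 nM, which is a limit of the assay and not a number. Compound 2 `CC(=O)OC[C@H]1O[C@@H](Cc2ccccc2)[C@H](OC(C)=O)[C@@H](OCc2ccccc2)[C@@H]1OC(C)=O` gives > 50000 nM, also a limit. Compound 3 `CC(=O)O[C@@H]1[C@@H](OC(C)=O)[C@H](Cc2ccccc2)O[C@H](COCc2ccccc2)[C@H]1OC(C)=O` gives > 50000 nM, again a limit, so it cannot be ranked against the other two. All the data so far come to one reading: the limit of > 50000 nM in this assay, at which 3 of the 3 values shown sit. Compound 4 `CC(=O)O[C@@H]1[C@@H](OCc2ccccc2)[C@H](OC(C)=O)[C@@H](COCc2ccccc2)O[C@H]1Cc1ccccc1` has benzyl in place of acetyl on an oxygen on a saturated carbon. Among the compounds with values here, no measured pair shows what this change does. With compound 3 at its limit of > 50000 nM, no step beyond the scatter is expected. The estimated change is a number no higher from compound 3 to compound 4 (the limit leaves the size open). For compound 4 the expected value is 50000 nM, with an estimated range from 25000 nM to 100000 nM.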

Compound 4, concentration for 50% growth inhibition: 6100 nM
Compound 4: middle estimate off by 8.2-fold (0.91 log units), on the high side, outside the stated range (below it).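

The swap of acetyl for benzyl on an oxygen on a saturated carbon turns out not to be silent: in this assay it gives an at least 8.1-fold lower number from compound 3 to compound 4 (0.91 log units; beyond the scatter), and the same swap gives an at least 8.1-fold lower number from compound 2 to compound 4 (0.91 log units; beyond the scatter). Compound 4 is thus the first compound here to give a real number, and the full size of both steps stays unknown, since their starting points are limits: the limit of > 50000 nM in this assay, at which 3 of the 4 values shown sit.

The compounds shown leave open whether this gain needs benzyl in particular, or whether a longer chain or an amine on this oxygen would serve as well.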